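A few compounds are considered here, and "the series" means these few. Any claim that something is new, unique, unknown or untested is made for them only; others in the source may bear on it.

Three compounds have been run in an assay on HEK293 cells for activation of Kir3.1/Kir3.2 (Homo sapiens), read by thallium flux; on this read-out higher numbers stand for an effect only at larger amounts of compound and lower numbers for an effect already at smaller amounts. Compound 1 `Cc1cc(NC(=O)Cn2nnc(-c3ccccc3)n2)n(C2CCS(=O)(=O)C2)n1` gives 1030 nM, compound 2 `Cc1cc(NC(=O)Cn2nnc(-c3ccc(Cl)c(Cl)c3)n2)n(C2CCCCC2)n1` gives 1220 nM, and compound 3 `Cc1cc(NC(=O)Cn2nnc(-c3ccccc3F)n2)n(C2CCCCC2)n1` gives 187 nM, the lowest of the three numbers; its gap to compound 1 and its gap to compound 2 are both beyond the scatter. Going by the values given here, the one single-change step so far is a 6.5-fold lower number from compound 2 to compound 3 (0.81 log units; beyond the scatter), which shows that what sits on the phenyl ring attached to the five-membered aromatic ring with four nitrogens moves this read-out well beyond the scatter.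

Compound 4 `COc1cccc(-c2nnn(CC(=O)Nc3cc(C)nn3C3CCCCC3)n2)c1` differs from compound 3 in 3-methoxyphenyl in place of 2-fluorophenyl on an aromatic carbon. The step from compound 2 to compound 3 bears on it only loosely, since neither its leaving nor its entering group appears there, and compound 1 carries a plain phenyl but also a different group on its ring nitrogen, so it gives no clean comparison. The expectation is therefore a moderate rise, a 2.4-fold higher number from compound 3 to compound 4 (0.38 log units; beyond the scatter), with wide uncertainty. Compound 4 is estimated at 450 nM, between 150 nM and 1400 nM.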

Compound 4, half-maximal effective concentration: 117 nM
Compound 4: middle estimate off by 3.8-fold (0.59 log units), on the high side; measured number outside the range, below it.
By their numbers in this assay, from the lowest: compounds 4 and 3 (each within the scatter of the next); then compounds 1 and 2 (each within the scatter of the next).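

In this assay, placing 3-methoxyphenyl in place of 2-fluorophenyl on the aromatic carbon of the five-membered ring with four nitrogens gives a 1.6-fold lower number from compound 3 to compound 4 (0.20 log units; within the scatter), so this change does not separate the two groups, although the entering group carries 1 hydrogen-bond acceptor and the leaving group none. Measured against 3,4-dichlorophenyl, the same 3-methoxyphenyl gives a 10-fold lower number from compound 2 to compound 4 (1.02 log units; beyond the scatter), which runs the same way as a 6.5-fold lower number from compound 2 to compound 3 (0.81 log units; beyond the scatter) and shows that this position tolerates two quite different phenyl groups on the low side of compound 2. Nothing at hand explains why these groups read as they do.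

Going by these compounds, how a 2-methoxyphenyl or a 3-fluorophenyl would read at this place stays open, and with it whether the group or its location on the phenyl ring matters more. Also open, on these data alone, is what an amine or a carboxylic acid on that phenyl ring would do to the read-out.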